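Removal of the chloro substituent from the ester-bearing phenyl ring

The compounds below may be only part of what the source reports. "The series", "measured", "known", "first", "only" and "open" are said of these compounds alone.

Measured compounds:
- compound 1, `COC(=O)c1c(F)cccc1OC(=O)COc1cc(O)c2c(=O)cc(-c3ccccc3)oc2c1`: 40300 nM
- compound 2, `COC(=O)c1cccc(Cl)c1OC(=O)COc1cc(O)c2c(=O)cc(-c3ccccc3)oc2c1`: 38700 nM

In a functional assay on cells (T-cell, Mus musculus, strain BALB/c) for inhibition, read by MTT assay, with a stated time of 72 h (a higher number here means a weaker inhibitor, a lower number a stronger inhibitor), compound 2 gives the lower of the two numbers shown so far, yet the step of a 1.0-fold lower number from compound 1 to compound 2 (0.02 log units; within the scatter) lies within the scatter, so compound 1 and compound 2 are indistinguishable on these data. Among the measured compounds shown here, that single step is the only one available for comparison, and it exchanges one halogenated, ester-bearing phenyl for another; it does not remove a halogen outright.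

Compound 3, `COC(=O)c1ccccc1OC(=O)COc1cc(O)c2c(=O)cc(-c3ccccc3)oc2c1`, is the next member of the series and has yet to be tested. It differs from compound 2 by hydrogen in place of chloro on an aromatic carbon, a loss of one heavy atom on the aromatic carbon described, with the methoxycarbonyl group retained.

The swap of the halogen between the two ring positions in the step from compound 1 to compound 2 moved the number by nothing beyond scatter. On that basis the removal of the chloro is expected to leave the number essentially where compound 2 stands, so the step of a 1.0-fold higher number from compound 2 to compound 3 (0.01 log units; within the scatter) is estimated to fall within the scatter, in no particular direction. Compound 3 is therefore expected to give about 40000 nM, within a range of 20000 nM to 85000 nM.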

Compound 3, half-maximal inhibitory concentration: 28500 nM
The estimate for compound 3 lay 1.4-fold (0.15 log units) above the measured number; the range from low to high includes it.
By their numbers in this assay, from the lowest: compounds 3, 2 and 1 (each within the scatter of the next).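

In this assay the bare ring of compound 3 gives a 1.4-fold lower number from compound 2 to compound 3 (0.13 log units; within the scatter) and a 1.4-fold lower number from compound 1 to compound 3 (0.15 log units; within the scatter) and so stays within reach of both halogenated compounds, which means hydrogen, chloro and fluoro cannot be told apart on this ester-bearing phenyl ring. The earlier pair only exchanged one halogenated ring for another, whereas the 2-(methoxycarbonyl)phenyl group of compound 3 shows that the number stays in the same range with no halogen on the ring at all. No measurement is at hand that would explain why the three compounds sit together.

The compounds shown leave open whether a group of another kind on this ring, such as an amine or a methoxy group, would move the number beyond the scatter. They also leave open whether the methoxycarbonyl group itself matters, which a carboxylic acid or an amide in its place would test, since all three compounds carry that ester unchanged.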